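This account rests on a few compounds, and the source may have more. Where it says the series, first, only, none or still open, it means among the compounds named here.

Compound 1 `Cc1cccc(/C=N/c2ccc(OCc3ccccc3)cc2)c1O` gives in a functional assay, with a stated time of 30 min (on this read-out higher numbers stand for weaker inhibition and lower numbers for stronger inhibition), only a limit, > 200000 nM, so its standing on the numbers is not fixed beyond that. Compound 2 `Oc1ccc(/C=N/c2ccc(OCc3ccccc3)cc2)c(O)c1` also returns a limit in this assay, > 200000 nM. Compound 3 `Oc1ccc(Br)cc1/C=N/c1ccc(OCc2ccccc2)cc1` likewise sits at a limit, > 200000 nM. The steps a step that the two limits leave unreadable from compound 1 to compound 2, a step that the two limits leave unreadable from compound 1 to compound 3 and a step that the two limits leave unreadable from compound 2 to compound 3 can therefore not be sized, because of the limit of > 200000 nM in this assay, at which 3 of the 3 values shown sit. Compound 4 `Cc1ccc(O)c(/C=N/c2ccc(OCc3ccccc3)cc2)c1` differs from compound 1 by 2-hydroxy-5-methylphenyl in place of 2-hydroxy-3-methylphenyl on a carbon with a double bond to nitrogen. Among the compounds with values here, no measured step touches this change in the same way; the measured steps replace the whole aryl group on the carbon with a double bond to nitrogen and every one of them ends at the limit. On that basis compound 4 is expected to remain at the limit as well, with no readable step in either direction. The step from compound 1 to compound 4 is thus expected to be a step that the limit leaves unreadable from compound 1 to compound 4. For compound 4 the estimate in this assay is 300000 nM, with a range from 100000 nM to 1000000 nM, and most likely the assay reports only a limit.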

Compound 4, half-maximal inhibitory concentration: > 200000 nM
Compound 4: only a limit was reported (the forecaster's own chance of this, stated with the estimate: 90%); the middle value is on the limit's open side.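

The steps to compound 4 from compound 1, compound 2 and compound 3 cannot be read in this assay, because all four compounds give only a limit: the limit of > 200000 nM in this assay, at which 4 of the 4 values shown sit. The compounds shown leave open whether any group on the carbon with a double bond to nitrogen gives a readable value in this assay.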